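Chloropurine benzyl series: effect of a second ring chloro

The compounds below may be only part of what the source reports. "The series", "measured", "known", "first", "only" and "open" are said of these compounds alone.

Measured compounds in a functional assay on NCI-H226 cells (Homo sapiens) for cytotoxicity, read by sulforhodamine B assay, with a stated time of 48 h; on this read-out higher numbers stand for weaker inhibition of growth and lower numbers for stronger inhibition of growth:
compound 1 `ClCc1ccc(Cn2cnc3c(Cl)ncnc32)cc1` — 1580 nM
compound 2 `ClCc1ccccc1Cn1cnc2c(Cl)nc(Cl)nc21` — 1730 nM

Compound 1 gives the lowest of the two numbers in this assay ; compound 2 is nearest, and its value lies within the scatter of that of compound 1, so the two are not distinguishable here.

Compound 3 `ClCc1ccc(Cn2cnc3c(Cl)nc(Cl)nc32)cc1` is not yet measured in this assay . It differs from compound 1 only by chloro in place of hydrogen on an aromatic carbon of the shared core.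

Among the compounds with values here, no step between measured compounds bears on this change. The two values in hand show that compound 2, which carries the same pair of chloro groups on the core as compound 3, sits level with compound 1. The expected step from compound 1 to compound 3 is therefore none beyond the scatter, a 1.1-fold lower number from compound 1 to compound 3 (0.02 log units; within the scatter). Compound 3 is estimated at 1500 nM, with a range from 600 nM to 4000 nM.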

Compound 3, concentration for 50% growth inhibition: 3550 nM
For compound 3 the middle estimate is 2.4-fold (0.37 log units) below the measured one, within the range that was stated.
By their numbers in this assay, from the lowest: compounds 1 and 2 (each within the scatter of the next); then compound 3.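

In this assay, within the data shown here, chloro in place of hydrogen on the aromatic carbon between two ring nitrogen atoms gives a 2.2-fold higher number from compound 1 to compound 3 (0.35 log units; beyond the scatter), the first directly read step at this position and one towards weaker inhibition of growth. This is a modest step from a single pair, so it marks this position as responsive to the change on this scaffold but sets no trend for the series. Nothing measured on these compounds accounts for the step.

Still open, going by these compounds, is how other groups at this position compare with hydrogen and chloro, for example an amine, a methoxy group or a longer chain. Also open, on these data alone, is whether the same change gives a step of similar size when the chloromethyl group stands elsewhere on the benzyl ring.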